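The source may report more compounds than this note shows. Statements on the series, on what has been measured and on what is new or still open speak of the compounds shown alone.

Three compounds have readings in an ADME assay on L132 cells (Homo sapiens) for cytotoxicity, read by MTT assay, with a stated time of 48 h; a higher number here means a weaker inhibitor, a lower number a stronger inhibitor. Compound 1 (`C/C(=C\CC/C(C)=C/CC[C@@H]1[C@@]2(C)CCC(=O)C(C)(C)[C@H]2CC[C@@]1(C)O)CC/C=C(\C)C(=O)OCc1cn(-c2ccc([N+](=O)[O-])cc2)nn1`) gives > 150000 nM as its result, and this is a limit of the assay, not a number. Compound 2 (`C/C(=C\CC/C(C)=C/CC[C@@H]1[C@@]2(C)CCC(=O)C(C)(C)[C@H]2CC[C@@]1(C)O)CC/C=C(\C)C(=O)OCc1cn(-c2cccc(Br)c2)nn1`) gives > 150000 nM as its result, again a limit only. Among the measured compounds shown here, compound 3 (`C/C(=C\CC/C(C)=C/CC[C@@H]1[C@@]2(C)CCC(=O)C(C)(C)[C@H]2CC[C@@]1(C)O)CC/C=C(\C)C(=O)OCc1cn(-c2cccc(Cl)c2)nn1`) gives 94200 nM as its result, the only actual number of the three, so its standing rests on a single reading against (the limit of > 150000 nM in this assay, at which 2 of the 3 values shown sit).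

Compound 4 (`C/C(=C\CC/C(C)=C/CC[C@@H]1[C@@]2(C)CCC(=O)C(C)(C)[C@H]2CC[C@@]1(C)O)CC/C=C(\C)C(=O)OCc1cn(-c2cccc(O)c2)nn1`) departs from compound 3 by hydroxy in place of chloro on an aromatic carbon, with hydroxy in place of chloro on an aromatic carbon, meta to a large group. The closest measured swap is an at least 1.5-fold lower number from compound 2 to compound 3 (0.20 log units; that floor lies within the scatter), and the exchange of the whole aryl group gives an at least 1.5-fold lower number from compound 1 to compound 3 (0.20 log units; that floor lies within the scatter). The remaining pair shows a step that the two limits leave unreadable from compound 1 to compound 2. For the measured compounds named here, both readable steps are floors within the scatter, and no measured step puts hydroxy on this ring. A step beyond the scatter is therefore not expected in this assay, with only a slight lean towards a higher number given (the limit of > 150000 nM in this assay, at which 2 of the 3 values shown sit). The expected move is a 1.3-fold higher number from compound 3 to compound 4 (0.11 log units; within the scatter), which stays inside the scatter. For compound 4 the estimated value is 120000 nM, with an expected range from 60000 nM to 220000 nM, and a report of the limit alone would be no surprise.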

Compound 4, half-maximal inhibitory concentration: 146000 nM
Estimate against measurement, compound 4: 1.2-fold (0.09 log units) below, and the stated range covers the measured number.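

In this assay, among the compounds shown here, hydroxy in place of chloro on an aromatic carbon, meta to a large group, is the first change that can be read between two actual numbers, and it gives a 1.5-fold higher number from compound 3 to compound 4 (0.19 log units; within the scatter). A hydrogen-bond donor and a hydrogen-bond acceptor therefore enter at this position where chloro had neither, without a step beyond the scatter. Against the two compounds that read only as limits, the steps are floors and add little, an at least 1.0-fold lower number from compound 2 to compound 4 (0.01 log units; that floor lies within the scatter) and an at least 1.0-fold lower number from compound 1 to compound 4 (0.01 log units; that floor lies within the scatter), and the series remains crowded at the top of the assay's range: the limit of > 150000 nM in this assay, at which 2 of the 4 values shown sit.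

Whether any group on this aromatic carbon can move the reading beyond the scatter remains open, since an amine or a carboxylic acid in place of the hydroxy is not among the compounds shown. Also open, from the compounds shown here alone, is how a methoxy group would read here, and whether the hydrogen on the hydroxy matters at all to this reading or the oxygen alone would give the same number.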